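Swapping Bromo for Cyano: What to Expect for Compound 3

The compounds below may be only part of what the source reports. "The series", "measured", "known", "first", "only" and "open" are said of these compounds alone.

Measured so far:
compound 1, `Brc1cncc(N2CC[C@@H]3CN[C@@H]3C2)c1`: 950 nM
compound 2, `Brc1cc(N2CC[C@@H]3CN[C@@H]3C2)cnc1Br`: 110 nM

Both were tested in a functional assay on HEK293 cells for agonist activity at Neuronal acetylcholine receptor; alpha3/beta4 (Homo sapiens), read by FLIPR; a lower number here means that less compound is needed, a higher number that more compound is needed for the effect. Among the measured compounds shown here, compound 1 has the higher of the two numbers; the only neighbour is compound 2, reached by an 8.6-fold lower number from compound 1 to compound 2 (0.94 log units; beyond the scatter). Compound 3, `N#Cc1cncc(N2CC[C@@H]3CN[C@@H]3C2)c1`, has not yet been measured. It differs from compound 1 by cyano in place of bromo on an aromatic carbon. For the measured compounds named here, no measured step replaces bromo with cyano. Going by the values given here, the single step seen, an 8.6-fold lower number from compound 1 to compound 2 (0.94 log units; beyond the scatter), adds a bromo rather than exchanging the one present, so it says nothing about what removing that bromo and putting cyano in its place does. Without a comparable step, the cyano analogue is expected to stay near compound 1, with wide uncertainty in both directions. Compound 3 is therefore estimated at about 1000 nM in this assay, within 300 nM to 3500 nM. The expected step from compound 1 to compound 3 is a 1.1-fold higher number from compound 1 to compound 3 (0.02 log units; within the scatter).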

Compound 3, half-maximal effective concentration: 490 nM
Compound 3: the middle estimate sits 2.0-fold (0.31 log units) above what was measured, and the stated range covers the measured number.
By their numbers in this assay, from the lowest: compound 2; then compounds 3 and 1 (each within the scatter of the next).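

Exchanging the bromo for a cyano on this aromatic carbon, two atoms from the ring nitrogen, gives a 1.9-fold lower number from compound 1 to compound 3 (0.29 log units; within the scatter) in this assay, so the two compounds cannot be told apart here. Among the compounds shown here, this is the first direct exchange at this position, and it shows that the bromo is not needed for this level of activity: a cyano, with two heavy atoms in place of one and a hydrogen-bond acceptor, serves as well in this assay. Nothing available explains why the two groups read alike.

From the compounds shown here alone, whether a methoxy group, an amine or a carboxylic acid on the same carbon would also read alike remains open. So does whether the second bromo of compound 2 would bring a similar step when added to compound 3.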